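Swapping the triazole substituent in a lactone series

The compounds below may be only part of what the source reports. "The series", "measured", "known", "first", "only" and "open" are said of these compounds alone.

Three compounds share one core. Compound 1 `CC(C)(C)c1cn(C[C@H](O)[C@H]2OC(=O)C(OCc3ccccc3)=C2OCc2ccccc2)nn1` carries a tert-butyl group; in a functional assay on A549 cells (Homo sapiens) for antiproliferative activity, read by MTT assay, with a stated time of 72 h (on this read-out higher numbers stand for weaker inhibition and lower numbers for stronger inhibition), compound 1 gives 34000 nM. Compound 2 `O=C1O[C@H]([C@@H](O)Cn2cc(CNS(=O)(=O)c3ccc(Cl)cc3F)nn2)C(OCc2ccccc2)=C1OCc1ccccc1` gives 39100 nM and compound 3 `O=C1O[C@H]([C@@H](O)Cn2cc(CNS(=O)(=O)c3ccc(F)cc3)nn2)C(OCc2ccccc2)=C1OCc1ccccc1` gives 22500 nM. Compound 3 is the starting point here, yet its separation from the others is small: a 1.5-fold lower number from compound 1 to compound 3 (0.18 log units; within the scatter) and a 1.7-fold lower number from compound 2 to compound 3 (0.24 log units; within the scatter).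

Compound 4 `Cc1ccc(-c2cn(C[C@H](O)[C@H]3OC(=O)C(OCc4ccccc4)=C3OCc3ccccc3)nn2)cc1` differs from compound 3 in one place: 4-methylphenyl in place of (((4-fluorophenyl)sulfonyl)amino)methyl on an aromatic carbon. The nearest guide is the change from compound 1 to compound 3, which swapped a group at that same aromatic carbon and moved the number only within the scatter. On that basis no step beyond the scatter is expected in this assay, and compound 4 is estimated at a 1.1-fold higher number from compound 3 to compound 4 (0.05 log units; within the scatter), giving about 25000 nM within a range of 8000 nM to 80000 nM.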

Compound 4, half-maximal inhibitory concentration: 8690 nM
The estimate for compound 4 lay 2.9-fold (0.46 log units) above the measured number; the range from low to high includes it.
By their numbers in this assay, from the lowest: compound 4; then compounds 3, 1 and 2 (each within the scatter of the next).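

In this assay this aromatic carbon can move the number beyond the scatter, as the earlier swap here did not: 4-methylphenyl brings a 2.6-fold lower number from compound 3 to compound 4 (0.41 log units; beyond the scatter) and a 3.9-fold lower number from compound 1 to compound 4 (0.59 log units; beyond the scatter) as modest steps. The gain appears with a group that has an aromatic ring, like the sulfonyl-bearing group it replaces, but lacks that group's hydrogen-bond donor and acceptors. Nothing at hand explains the change.

Going by these compounds, whether the ring alone or its methyl carries the step stays open. Plain phenyl or 4-methoxyphenyl at this carbon would help separate the two.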